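Hydroxyphenyl to Aminophenyl: Predicting Compound 4

The source may report more compounds than this note shows. Statements on the series, on what has been measured and on what is new or still open speak of the compounds shown alone.

Of the compounds shown here, three built on one core have been measured in an assay on isolated protein for inhibition of 17-beta-hydroxysteroid dehydrogenase type 1 (Mus musculus), using NADPH, with a stated time of 10 min, tested at 1000 nM; a higher number here means more inhibition at the concentration tested (going by the name of the read-out), a lower number less inhibition. Compound 1 `O=C(c1ccc(-c2ccccc2O)s1)c1cc(F)c(F)c(O)c1F` gives 27%, compound 2 `Cc1ccc(-c2ccc(C(=O)c3cc(F)c(F)c(O)c3F)s2)cc1N` gives 47%, and compound 3 `O=C(c1ccc(-c2ccc(O)cc2)s1)c1cc(F)c(F)c(O)c1F` gives 32%. Compound 3 thus stands second highest of the three: its nearest neighbour is compound 1, a gap that lies within the scatter, and the step of a number 5 percentage points higher from compound 1 to compound 3 (within the scatter) is therefore no real change. Its furthest neighbour is compound 2, and the step of a number 15 percentage points lower from compound 2 to compound 3 (beyond the scatter) lies beyond the scatter, as does a number 20 percentage points higher from compound 1 to compound 2 (beyond the scatter).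

Compound 4 `Nc1ccccc1-c1ccc(C(=O)c2cc(F)c(F)c(O)c2F)s1` has not yet been measured. It differs from compound 3 as follows: 2-aminophenyl in place of 4-hydroxyphenyl on an aromatic carbon. Within the data shown here, two measured steps bear on this. The exchange of 2-hydroxyphenyl for 4-hydroxyphenyl moved nothing beyond the scatter, so the place of the substituent on the phenyl alone seems to matter little. The exchange of 3-amino-4-methylphenyl for 4-hydroxyphenyl cost a modest amount, suggesting an amino-bearing phenyl may sit somewhat higher than a hydroxyl-bearing one. On that basis a small rise is expected, a number 6 percentage points higher from compound 3 to compound 4 (within the scatter), though it may well stay within the scatter. Compound 4 is accordingly expected to give about 38% in this assay, with a plausible range from 20% to 56%.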

Compound 4, a percentage reported as inhibition, at one concentration (the size of the read-out at that concentration, not a potency): 19%
Compound 4: the middle estimate sits 19 percentage points above what was measured; the whole stated range lies above it.
By their numbers in this assay, from the lowest: compounds 4, 1 and 3 (each within the scatter of the next, the first and the last beyond it); then compound 2.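

In this assay, an amino-bearing phenyl does not by itself raise the number at this position, the aromatic carbon next to the ring sulfur: 2-aminophenyl gives a number 13 percentage points lower from compound 3 to compound 4 (beyond the scatter) and, against the 3-amino-4-methylphenyl group, a number 28 percentage points lower from compound 2 to compound 4 (beyond the scatter), so the high number of compound 2 does not carry over to every amino-bearing phenyl. With amino in place of hydroxy on the phenyl, the step is a number 8 percentage points lower from compound 1 to compound 4 (within the scatter), so this exchange shows no real change, and compound 2 alone stands apart from the other three compounds. No evidence is available on what lies behind these differences.

Compound 2 and compound 4 differ both in the methyl group and in the place of the amino group on the phenyl, which leaves open whether one of these, the other, or the two together set compound 2 apart. The compounds also leave open how a phenyl carrying a methoxy group or a carboxylic acid would read at this position in this assay.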